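A few compounds are considered here, and "the series" means these few. Any claim that something is new, unique, unknown or untested is made for them only; others in the source may bear on it.

Three compounds have been measured in an assay on isolated protein for binding affinity to Discoidin domain-containing receptor 2 (Homo sapiens), read by thermal shift assay, tested at 10 uM; a lower number here means that the compound stabilises the target less, a higher number that the compound stabilises the target more against heat:

compound 1, `CS(=O)(=O)N1CCCC(NC(=O)[C@H](CCC2CCCCC2)NC(=O)c2ccc(CNC(=O)c3cc(-c4ccccc4)n[nH]3)cc2)C1`: 2 degrees C
compound 2, `CC(NC(=O)c1cc(-c2ccccc2)n[nH]1)c1ccc(C(=O)N[C@@H](CCC2CCCCC2)C(=O)NC2CCCN(S(C)(=O)=O)C2)cc1`: 1.7 degrees C
compound 3, `CCCNC(=O)[C@H](CCC1CCCCC1)NC(=O)c1ccc(CNC(=O)c2cc(-c3ccccc3)n[nH]2)cc1`: 1.1 degrees C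

Among these three, compound 1 holds the highest number, but neither gap separates it from the others: a number 0.30 degrees C lower from compound 1 to compound 2 (within the scatter) and a number 0.90 degrees C lower from compound 1 to compound 3 (within the scatter) both fall within the scatter of repeated measurements, so the three compounds read as equivalent in this assay.

Compound 4, `Cn1ncc(C(=O)NCc2ccc(C(=O)N[C@@H](CCC3CCCCC3)C(=O)NC3CCCN(S(C)(=O)=O)C3)cc2)c1N`, differs from compound 1 at the far end of the molecule: a group of 7 heavy atoms (4 carbon, 3 nitrogen; one five-membered aromatic ring with 2 hetero atoms) in place of a group of 11 heavy atoms (9 carbon, 2 nitrogen; one five-membered aromatic ring with 2 hetero atoms, one six-membered aromatic ring of carbon only), on a carbonyl carbon. Within the data shown here, the leaving group carries a six-membered aromatic ring of carbon only that the entering group lacks, and the entering group brings two additional hydrogen-bond acceptors. Neither measured step touches this part of the molecule; the steps from compound 1 to compound 2 and from compound 1 to compound 3 alter the linker and the amide substituent and were both within the scatter. They therefore say little about the present change, which is larger in atom count than either. On that basis a modest loss is expected, estimated as a number 1.2 degrees C lower from compound 1 to compound 4 (beyond the scatter), giving compound 4 an expected value of 0.8 degrees C with a range from -0.5 degrees C to 2.2 degrees C.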

Compound 4, shift of the target's melting temperature: 8.7 degrees C
The estimate for compound 4 lay 7.9 degrees C below the measured number; the measured number lies above the stated range.
By their numbers in this assay, from the lowest: compounds 3, 2 and 1 (each within the scatter of the next); then compound 4.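

The group on the carbonyl carbon matters far more in this assay than the parts changed earlier: exchanging 3-phenyl-1H-pyrazol-5-yl for the smaller group gives a number 6.7 degrees C higher from compound 1 to compound 4 (beyond the scatter) and so stands apart from the changes at the linker and the amide substituent, where a number 0.30 degrees C lower from compound 1 to compound 2 (within the scatter) and a number 0.90 degrees C lower from compound 1 to compound 3 (within the scatter) were small. In this one pair, then, the six-membered aromatic ring of carbon only is not required for strong stabilisation of the target against heat, and a group with fewer heavy atoms and more hydrogen-bond acceptors reads much higher on an otherwise unchanged molecule. No measurement at hand accounts for this rise.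

This single step removes the phenyl ring and alters the substituents on the five-membered ring together, so it cannot show which of these changes carries the rise; a match with only the amine replaced by a hydroxyl group, or with the methyl on the ring replaced by a longer chain such as ethyl, would begin to separate them. Going by these compounds, it also remains open whether the methyl and propyl changes would stay as small when combined with the new group.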